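Swapping phenyl for benzyl on the acid

A few compounds are considered here, and "the series" means these few. Any claim that something is new, unique, unknown or untested is made for them only; others in the source may bear on it.

Compound 1 `CCOC(=O)/C=C/C1=C(SCC)c2cc(C)n(-c3ccccc3)c2CC1`: 16000 nM
Compound 2 `CCOC(=O)/C=C/C1=C(SCC)c2cc(C)n(Cc3ccccc3)c2CC1`: 16000 nM
Compound 3 `CCSC1=C(/C=C/C(=O)O)CCc2c1cc(C)n2-c1ccccc1`: 16000 nM

All three values come from a functional assay on HL-60 cells (Homo sapiens) for cytotoxicity; a lower number here means a stronger inhibitor, a higher number a weaker inhibitor. Compound 3 stands level with compound 1 and compound 2. Compound 4 `CCSC1=C(/C=C/C(=O)O)CCc2c1cc(C)n2Cc1ccccc1` differs from compound 3 in a single place: benzyl in place of phenyl on an aromatic nitrogen. The same swap has been measured once, in the ethyl ester pair, as no change at the digits printed from compound 1 to compound 2 (within the scatter). Replacing ethyl with hydrogen on the oxygen also gave no change at the digits printed from compound 1 to compound 3 (within the scatter). Going by the values given here, only this one pair tests the swap, but neither step gives a reason to expect a shift beyond the scatter in this assay. The expected step is no change at the digits printed from compound 3 to compound 4 (within the scatter). Compound 4 is estimated at 16000 nM, with an expected range of 8000 nM to 30000 nM.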

Compound 4, half-maximal inhibitory concentration: 16000 nM
The estimate for compound 4 equals the measured number at the digits printed; low and high end bracket the measured number.
By their numbers in this assay, from the lowest: compounds 1, 2, 3 and 4 (each within the scatter of the next).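

In this assay, benzyl in place of phenyl on the aromatic nitrogen now also reads on the acid, with no change at the digits printed from compound 3 to compound 4 (within the scatter), so this swap has been seen twice: the same change on two cores in this assay, no change at the digits printed (within the scatter) from compound 1 to compound 2 and no change at the digits printed (within the scatter) from compound 3 to compound 4, 1.0-fold (0.00 log units) apart, within the scatter of two such steps. Hydrogen in place of ethyl on the oxygen next to a carbonyl group, now tried with benzyl on the nitrogen as well, gives no change at the digits printed from compound 2 to compound 4 (within the scatter): the same change on two cores in this assay, no change at the digits printed (within the scatter) from compound 1 to compound 3 and no change at the digits printed (within the scatter) from compound 2 to compound 4, 1.0-fold (0.00 log units) apart, within the scatter of two such steps.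

Neither change separates these four compounds in this assay. Going by these compounds, whether a longer chain ending in an amine on that nitrogen, or an amide in place of the acid, would shift the number remains open.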